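Swapping an aminopyridine for a fluoropyridine on a shared core

The source may report more compounds than this note shows. Statements on the series, on what has been measured and on what is new or still open speak of the compounds shown alone.

Within the data shown here, compound 2 `CCCN(CCC)c1cc(C)nc2c(-c3ncc(F)cc3C)c(C)nn12` holds the lower of the two numbers measured so far in an assay on isolated protein for binding affinity to corticotropin-releasing factor receptor 1 (Homo sapiens) (a lower number here means a stronger inhibitor, a higher number a weaker inhibitor), where compound 2 gives 19 nM. Among the measured compounds shown here, its nearest neighbour is compound 1 `CCCN(CCC)c1cc(C)nc2c(-c3ncc(NC)cc3C)c(C)nn12`, which in this assay gives 40 nM; the single measured step, a 2.1-fold lower number from compound 1 to compound 2 (0.32 log units; beyond the scatter), replaces methylamino with fluoro on an aromatic carbon. Compound 3 `CCCN(CCC)c1cc(C)nc2c(-c3ncc(C)cc3N)c(C)nn12` has not yet been measured; it differs from compound 2 by 3-amino-5-methylpyridin-2-yl in place of 5-fluoro-3-methylpyridin-2-yl on an aromatic carbon. For the measured compounds named here, the one step that bears on this exchange also traded a nitrogen-bearing group for fluorine, and the change to compound 3 runs the other way, reinstating a nitrogen-bearing group in place of the fluorine. A modest rise in this assay is therefore expected, roughly the size of the step already seen. Compound 3 is estimated at 45 nM, within 15 nM to 135 nM, which corresponds to an expected step of a 2.4-fold higher number from compound 2 to compound 3 (0.37 log units; beyond the scatter).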

Compound 3, inhibition constant: 40 nM
The estimate for compound 3 lay 1.1-fold (0.05 log units) above the measured number; low and high end bracket the measured number.
By their numbers in this assay, from the lowest: compound 2; then compounds 1 and 3 (each within the scatter of the next).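

In this assay, the 3-amino-5-methylpyridin-2-yl group gives a 2.1-fold higher number from compound 2 to compound 3 (0.32 log units; beyond the scatter), so the 5-fluoro-3-methylpyridin-2-yl group now holds the lower number against two different nitrogen-bearing pyridine groups rather than one. Comparing those two nitrogen-bearing groups gives no change at the digits printed from compound 1 to compound 3 (within the scatter), so this position does not separate the amino group from the methylamino group, even though the two groups are arranged differently on the pyridine. Nothing available explains why the fluoro compound gives the lower number.

Open still is whether that lower number is specific to fluorine, since a chloro or methoxy group in its place would test this. Also open, from the compounds shown here alone, is whether a pyridine carrying a dimethylamino group or a longer alkylamino chain would match the amino and methylamino compounds.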